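The compounds below may be only part of what the source reports. "The series", "measured", "known", "first", "only" and "open" are said of these compounds alone.

Measured so far in a functional assay on HUVEC cells (Homo sapiens) for cytotoxicity; on this read-out lower numbers stand for an effect already at smaller amounts and higher numbers for an effect only at larger amounts of compound:
- compound 1 `COC1=C(C)C(=O)/C(=C(O)/C=C/c2ccc(OC)cc2)C(=O)C1(C)C`: 2.5 ug/mL
- compound 2 `COC1=C(C)C(=O)/C(=C(O)/C=C/c2ccc(O)cc2)C(=O)C1(C)C`: 3.8 ug/mL
- compound 3 `COC1=C(C)C(=O)/C(=C(O)/C=C/c2cc(C)cc(C)c2)C(=O)C1(C)C`: 2.5 ug/mL

Compound 3 stands level with compound 1 on these numbers, and compound 2 lies within the scatter of both. Compound 4 `C=Cc1ccccc1/C=C/C(O)=C1/C(=O)C(C)=C(OC)C(C)(C)C1=O` is reached from compound 3 by one change (2-vinylphenyl in place of 3,5-dimethylphenyl on a double-bonded chain carbon bound to a double-bonded chain carbon), which puts 2-vinylphenyl in place of 3,5-dimethylphenyl on a double-bonded chain carbon bound to a double-bonded chain carbon.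

Two measured steps change the aromatic group at this same place. They are no change at the digits printed from compound 1 to compound 3 (within the scatter) and a 1.5-fold lower number from compound 2 to compound 3 (0.18 log units; within the scatter). The step of a 1.5-fold higher number from compound 1 to compound 2 (0.18 log units; within the scatter), made on that aromatic group, is also small. Within the data shown here, none of the measured compounds carries a vinyl group, so the data do not test that feature directly. On the measured steps, no change beyond the scatter is expected in this assay. The expected step is a 1.1-fold higher number from compound 3 to compound 4 (0.05 log units; within the scatter). The estimate for compound 4 is 2.8 ug/mL, with an expected range from 1.3 ug/mL to 6 ug/mL.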

Compound 4, concentration for half-maximal effect: 1.1 ug/mL
Estimate against measurement, compound 4: 2.5-fold (0.41 log units) above, outside the stated range (below it).
By their numbers in this assay, from the lowest: compound 4; then compounds 1, 3 and 2 (each within the scatter of the next).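

In this assay, among these compounds, the aromatic group on a double-bonded chain carbon bound to a double-bonded chain carbon now moves the number beyond the scatter, which no step among the earlier compounds did. The 2-vinylphenyl group gives a lower number in place of 3,5-dimethylphenyl (a 2.3-fold lower number from compound 3 to compound 4 (0.36 log units; beyond the scatter)), in place of 4-methoxyphenyl (a 2.3-fold lower number from compound 1 to compound 4 (0.36 log units; beyond the scatter)) and in place of 4-hydroxyphenyl (a 3.5-fold lower number from compound 2 to compound 4 (0.54 log units; beyond the scatter)), so compound 4 has the lowest number of the four, although 2-vinylphenyl and 3,5-dimethylphenyl have the same count of heavy atoms. Nothing available explains this shift.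

The compounds shown do not tell whether the double bond outside the aromatic ring matters, as a 2-ethylphenyl group would show. From the compounds shown here alone, how an amine or a carboxylic acid on that aromatic ring would read here also stays open.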